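The source may hold more compounds than are shown below. What is called first, only, known or untested is meant among the compounds shown, and "the series" means these compounds.

Measured compounds:
- compound 1, `COc1ccccc1NCC(=O)Oc1ccc2c(C)cc(=O)oc2c1`, in a functional assay on the whole organism (strain Wistar albino) for inhibition, with Rattus norvegicus as the target, read by paw edema, with stated times of 30 min and 3 h, at a dose of 20 mg/kg by the oral route (a higher number here means more inhibition at the dose given (going by the name of the read-out), a lower number less inhibition), gives 26.6%
- compound 2, `Cc1cc(=O)oc2cc(OC(=O)CNc3ccccc3[N+](=O)[O-])ccc12`, in this assay gives 15.9%
- compound 3, `Cc1cc(=O)oc2cc(OC(=O)CNc3nc4ccccc4s3)ccc12`, in this assay gives 40.4%

Compound 1 stands second highest of the three; compound 2 sits below it, a number 10.7 percentage points lower from compound 1 to compound 2 (beyond the scatter), while compound 3 sits above it beyond the scatter. The unmeasured compound 4, `Cc1cc(=O)oc2cc(OC(=O)CNc3nccs3)ccc12`, differs from compound 1 in one place: 1,3-thiazol-2-yl in place of 2-methoxyphenyl on an amine nitrogen. Among the measured compounds shown here, no measured step covers this change; the only measured step, from compound 1 to compound 2, concerns a nitro group. For the measured compounds named here, the values of compound 1 and compound 3 show only that a ring with nitrogen and sulfur on the amine nitrogen went with the higher number. Compound 4 is therefore expected to give a modest upward step within the scatter, a number 6.4 percentage points higher from compound 1 to compound 4 (within the scatter). The estimate for compound 4 is 33%, between 20% and 46%.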

Compound 4, a percentage reported as inhibition, in the whole organism at one dose (the size of the read-out at that dose, not a potency): 47.8%
Compound 4: the middle estimate sits 14.8 percentage points below what was measured; the whole stated range lies below it.
By their numbers in this assay, from the lowest: compound 2; then compound 1; then compounds 3 and 4 (each within the scatter of the next).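

In this assay, the change of the whole ring on the amine nitrogen gives a number 21.2 percentage points higher from compound 1 to compound 4 (beyond the scatter), a step of the opposite sign to the only earlier one, which changed a group on the 2-substituted phenyl ring. This position therefore accepts a five-membered aromatic ring with 2 hetero atoms in place of the six-membered carbon ring, with fewer heavy atoms and a higher number at the dose given. Nothing at hand accounts for this rise.

Going by these compounds, it remains open whether the ring's sulfur or its nitrogen goes with the rise, which a 1,3-oxazol-2-yl or pyridin-2-yl group could test. On these data alone, a methyl group on the thiazole ring or a longer chain to the amine nitrogen also remains untested here.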